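Swapping an isopropyl for a pyrrolidine urea on the ring nitrogen

The source may hold more compounds than are shown below. What is called first, only, known or untested is meant among the compounds shown, and "the series" means these compounds.

Compound 1 `O=C(Nc1ccc(Cl)cc1)[C@H]1CNC[C@@H]1C(=O)Nc1ccc(-n2ccccc2=O)cc1F`, compound 2 `CCS(=O)(=O)N1C[C@H](C(=O)Nc2ccc(Cl)cc2)[C@@H](C(=O)Nc2ccc(-n3ccccc3=O)cc2F)C1` and compound 3 `CC(C)N1C[C@H](C(=O)Nc2ccc(Cl)cc2)[C@@H](C(=O)Nc2ccc(-n3ccccc3=O)cc2F)C1` share one core. In a physicochemical assay for lipophilicity, at pH 7.4 (on this read-out lower numbers stand for lower lipophilicity and higher numbers for higher lipophilicity), compound 2 gives 2.44, while compound 1 gives "not determined" (no result reported) and compound 3 gives "not determined" (no result reported) in this assay. So compound 3 stands without any measured anchor. Compound 4 `O=C(Nc1ccc(Cl)cc1)[C@H]1CN(C(=O)N2CCCC2)C[C@@H]1C(=O)Nc1ccc(-n2ccccc2=O)cc1F` differs from compound 3 by (pyrrolidin-1-yl)carbonyl in place of isopropyl on an amine nitrogen in a ring. With no value for compound 3, neither the size nor the direction of this step in this assay can be read from the numbers shown. For the measured compounds named here, the only guide is compound 2, which gives 2.44 in this assay. Compound 4 is therefore expected to fall near 2.7, within a range from 2.2 to 3.2.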

Compound 4, distribution coefficient: 2.78
Compound 4: the middle estimate sits 0.08 log units below what was measured, within the range that was stated.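

With (pyrrolidin-1-yl)carbonyl in place of ethylsulfonyl on the amine nitrogen in the ring, this assay gives a number 0.34 log units higher from compound 2 to compound 4 (beyond the scatter), so a change of group at this position shows up on this read-out, though only modestly. The step from isopropyl cannot be read: compound 3 carries no single number. Nothing at hand accounts for the shift. Going by these compounds, compound 1 also carries no number, so the effect of any group against the free ring nitrogen stays open. How an acetyl group, a morpholine urea or a longer alkyl chain would read here is also unknown.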